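From 3-chloropropyl to propanoyl in compound 2

The source may report more compounds than this note shows. Statements on the series, on what has been measured and on what is new or still open speak of the compounds shown alone.

In a functional assay on M21 cells (Homo sapiens) for antiproliferative activity, with a stated time of 48 h (a higher number here means a weaker inhibitor, a lower number a stronger inhibitor), compound 1 (`CCCCCc1cccc(NC(=O)NCCCCl)c1`) gives 24000 nM, compound 2 (`CCCCC(O)c1cccc(NC(=O)NCCCCl)c1`) gives 35000 nM and compound 3 (`CCCCC(OC)c1cccc(NC(=O)NCCCCl)c1`) gives 51000 nM. Compound 2 is not separated from either of the other two beyond the scatter: the steps are a 1.5-fold higher number from compound 1 to compound 2 (0.16 log units; within the scatter) and a 1.5-fold higher number from compound 2 to compound 3 (0.16 log units; within the scatter). Among the compounds with values here, only one pair separates, modestly, with a 2.1-fold higher number from compound 1 to compound 3 (0.33 log units; beyond the scatter).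

Compound 4 (`CCCCC(O)c1cccc(NC(=O)NC(=O)CC)c1`) has propanoyl in place of 3-chloropropyl on an amide-type nitrogen. Within the data shown here, none of the measured steps changes this substituent. All three concern only the hydroxy or methoxy on the saturated chain carbon, so they bear on the new step only indirectly, as a record of small movements in this assay. The data give no direction for the change, so no shift beyond the scatter is expected, though the uncertainty is wide. The expected change is a 1.1-fold higher number from compound 2 to compound 4 (0.06 log units; within the scatter). Compound 4 is estimated at 40000 nM, with an expected range of 15000 nM to 100000 nM.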

Compound 4, half-maximal inhibitory concentration: > 100000 nM
Compound 4: only a limit was reported; the forecaster's own chance of this, stated with the estimate: 20%; at least 2.5-fold (0.39 log units) between middle value and limit.
By their numbers in this assay, from the lowest: compounds 1, 2 and 3 (each within the scatter of the next, the first and the last beyond it). At a limit, above all of these: compound 4.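

In this assay compound 4 is reported only as a limit, > 100000 nM. Propanoyl in place of 3-chloropropyl on the amide-type nitrogen gives an at least 2.8-fold higher number from compound 2 to compound 4 (0.45 log units; beyond the scatter), so this substituent, which no earlier step changed, does matter in this series, and this exchange weakens the compound beyond the scatter. Only a minimum can be read for this step, and the true distance of compound 4 from compound 2 stays unknown: the limit of > 100000 nM in this assay, at which 1 of the 4 values shown sits.

Within the data shown here, the single step removes the chlorine and brings in the carbonyl together, so the two changes cannot be told apart; a plain propyl group on this nitrogen would separate them. Also open, on these data alone, is how a longer chloroalkyl chain or a terminal amine would read at this position, and whether the pentyl chain of compound 1 would give the same result with propanoyl.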